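Moving the methoxy on the aryl group of compound 2

The compounds below may be only part of what the source reports. "The series", "measured", "known", "first", "only" and "open" are said of these compounds alone.

Measured so far in a functional assay on LoVo cells (Homo sapiens) for inhibition, read by MTT assay, with a stated time of 24 h (on this read-out lower numbers stand for stronger inhibition and higher numbers for weaker inhibition), for this series:
- compound 1 `CC1(C)[C@H]2CC[C@]1(C)N(Cc1cn(-c3cccc(Br)c3)nn1)C(=O)C2` gives 30 nM in the first test of the pair
- compound 2 `COc1cccc(-n2cc(CN3C(=O)C[C@@H]4CC[C@@]3(C)C4(C)C)nn2)c1` gives 80 nM as the second

Among the compounds with values here, with only two numbers in hand, compound 2 at 80 nM is the higher of them and thus the weaker inhibitor of the pair. Within the data shown here, the single measured step, a 2.7-fold higher number from compound 1 to compound 2 (0.43 log units; beyond the scatter), comes from methoxy in place of bromo on an aromatic carbon. It is modest but beyond the scatter.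

Compound 3 `COc1ccc(-n2cc(CN3C(=O)C[C@@H]4CC[C@@]3(C)C4(C)C)nn2)cc1` keeps the same atoms joined differently, with 4-methoxyphenyl in place of 3-methoxyphenyl on an aromatic nitrogen as the whole change. Among the measured compounds shown here, no measured pair moves a group around this aryl ring, so the data give no direction for the change. For the measured compounds named here, the step of a 2.7-fold higher number from compound 1 to compound 2 (0.43 log units; beyond the scatter) is the only guide to size, and it replaces a group rather than moving one. A step no larger than that one is therefore expected in this assay, possibly none beyond the scatter.

The estimated change is a 1.1-fold lower number from compound 2 to compound 3 (0.06 log units; within the scatter) as a weakly held expectation. Compound 3 is expected at an estimated 70 nM, within a range from 25 nM to 200 nM as the likely span.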

Compound 3, half-maximal inhibitory concentration: 70 nM
Beside the measured number, compound 3's estimate shows no gap at the digits printed; the measured number falls inside the stated range.
By their numbers in this assay, from the lowest: compound 1; then compounds 3 and 2 (each within the scatter of the next).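

In this assay, the move from 3-methoxyphenyl to 4-methoxyphenyl on the aromatic nitrogen gives a 1.1-fold lower number from compound 2 to compound 3 (0.06 log units; within the scatter), so this first shift of a group around the aryl ring produces no difference that can be read from the scatter. The separation from the bromo compound persists with the methoxy in either placement: a 2.3-fold higher number from compound 1 to compound 3 (0.37 log units; beyond the scatter) stands alongside a 2.7-fold higher number from compound 1 to compound 2 (0.43 log units; beyond the scatter), so among these three compounds the readable difference follows the exchange of 3-bromophenyl for a methoxyphenyl group, not the placement of the methoxy. Nothing available here accounts for either the flat positional step or the persisting gap to the bromo compound.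

On these data alone, whether a bromo group would respond to the same move as the methoxy remains open, so the flat result applies to the methoxy pair alone. Also open, as far as these compounds go, is how this aryl ring behaves with a group of a different kind, such as an amine, a carboxylic acid or a longer alkoxy chain in place of the methoxy.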